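The source may hold more compounds than are shown below. What is called first, only, known or untested is meant among the compounds shown, and "the series" means these compounds.

Of the compounds shown here, three have been measured in an assay on isolated protein for inhibition of DNA topoisomerase 1 (Homo sapiens), with a stated time of 30 min, tested at 100 uM; on this read-out lower numbers stand for less inhibition and higher numbers for more inhibition at the one concentration tested (going by the name of the read-out). Compound 1 `Cc1ccccc1-c1cc(-c2ccoc2)cc(-c2ccc(Cl)s2)n1` gives 4.6%, compound 2 `Cc1cccc(-c2cc(-c3ccoc3)cc(-c3ccc(Cl)s3)n2)c1` gives 2.6% and compound 3 `Cc1ccc(-c2cc(-c3ccoc3)cc(-c3ccc(Cl)s3)n2)cc1` gives 0%. Compound 3 holds the lowest of the three numbers, yet its nearest neighbour is compound 2, a number 2.6 percentage points lower from compound 2 to compound 3 (within the scatter), and the furthest is compound 1, a number 4.6 percentage points lower from compound 1 to compound 3 (within the scatter); the remaining measured step, a number 2 percentage points lower from compound 1 to compound 2 (within the scatter), is also within the scatter, so none of the three is told apart from the others.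

Compound 4 `Clc1ccc(-c2cc(-c3ccoc3)cc(-c3ccccc3Cl)n2)s1` is not yet measured. It differs from compound 3 in one place: 2-chlorophenyl in place of 4-methylphenyl on an aromatic carbon. The three measured steps all exchange one methylphenyl for another on the same carbon and each left the read-out unchanged beyond the scatter. Among the measured compounds shown here, no measured step exchanges a methyl for a chlorine, so the change to compound 4 is not covered directly. For the measured compounds named here, because the aryl variations so far gave only a number 2 percentage points lower from compound 1 to compound 2 (within the scatter), a number 4.6 percentage points lower from compound 1 to compound 3 (within the scatter) and a number 2.6 percentage points lower from compound 2 to compound 3 (within the scatter), the expected step is a number 3 percentage points higher from compound 3 to compound 4 (within the scatter), nothing beyond the scatter. For compound 4 the estimate in this assay is 3%, expected to lie between 0% and 12%.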

Compound 4, a percentage reported as inhibition, at one concentration (the size of the read-out at that concentration, not a potency): 0%
Compound 4: the middle estimate sits 3 percentage points above what was measured; the measured number falls inside the stated range.
By their numbers in this assay, from the lowest: compounds 3, 4, 2 and 1 (each within the scatter of the next).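

In this assay, among the compounds shown here, the aromatic carbon next to the ring nitrogen now carries a chlorine-bearing phenyl group, which the earlier compounds did not show there, and the exchange for 4-methylphenyl gives no change at the digits printed from compound 3 to compound 4 (within the scatter) at this position. Chloro in place of methyl on the same phenyl group gives a number 4.6 percentage points lower from compound 1 to compound 4 (within the scatter) and 2-chlorophenyl in place of 3-methylphenyl gives a number 2.6 percentage points lower from compound 2 to compound 4 (within the scatter) so this change, like the moves of the methyl, separates no compound from another at the one concentration tested. Nothing available offers an explanation for this flat result.

Going by these compounds, whether any group at this position can lift the read-out beyond the scatter stays open, for instance an amine or a carboxylic acid on the phenyl ring. On these data alone, the furan-3-yl and 5-chlorothiophen-2-yl groups are the same in all four compounds, so what they contribute also stays open.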